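Dropping the methyl from the anilino ring of compound 1

This account rests on a few compounds, and the source may have more. Where it says the series, first, only, none or still open, it means among the compounds named here.

Measured compounds:
- compound 1, `Cc1ccc(Nc2cncc(N3CC4CC(C3)N4)c2)cc1`: 0.148 nM
- compound 2, `Clc1ccc(Nc2ccc(N3CC4CC(C3)N4)cn2)cc1`: 2.49 nM

Both compounds were tested in an assay on cell membranes for displacement of a labelled ligand from Neuronal acetylcholine receptor; alpha4/beta2 (Rattus norvegicus); on this read-out lower numbers stand for stronger inhibition and higher numbers for weaker inhibition. Compound 1 gives the lowest of the two numbers, with 0.148 nM, and compound 2 is the nearest, with 2.49 nM; that gap lies beyond the scatter, so compound 1 binds more tightly than compound 2. The two compounds differ in more than one place, so their values alone cannot be split into parts.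

Compound 3, `c1ccc(Nc2cncc(N3CC4CC(C3)N4)c2)cc1`, is not yet measured. It differs from compound 1 in one respect: hydrogen in place of methyl on an aromatic carbon, changing 4-methylphenyl to phenyl. Among the compounds with values here, no measured pair shows this change, so its size is open. A small weakening in this assay seems the most likely outcome, of a size a 2.4-fold higher number from compound 1 to compound 3 (0.37 log units; beyond the scatter), though a result within the scatter would not be surprising. Compound 3 is therefore expected to give about 0.35 nM, within 0.1 nM to 1.2 nM.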

Compound 3, inhibition constant: 0.0807 nM
The estimate for compound 3 lay 4.3-fold (0.64 log units) above the measured number; the measured number lies below the stated range.
By their numbers in this assay, from the lowest: compounds 3 and 1 (each within the scatter of the next); then compound 2.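

In this assay, hydrogen in place of methyl on an aromatic carbon, para to a large group, gives a 1.8-fold lower number from compound 1 to compound 3 (0.26 log units; within the scatter). Within the data shown here, this is the first matched pair for this change, and it shows that 4-methylphenyl and phenyl cannot be told apart here, so the very tight binding of compound 1 does not depend on the methyl. Nothing measured here explains why this position tolerates the change.

From the compounds shown here alone, it remains open whether a much larger or very different group on this carbon, such as a carboxylic acid, an amine or a longer chain, would keep the number in this range. The source of the gap to compound 2 also stays unresolved, since compound 2 differs from compound 1 and compound 3 in more than one place.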